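This account rests on a few compounds, and the source may have more. Where it says the series, first, only, none or still open, it means among the compounds named here.

Measured compounds in a functional assay on NCI-H460 cells (Homo sapiens) for inhibition, read by sulforhodamine B assay, with a stated time of 48 h; on this read-out higher numbers stand for weaker inhibition of growth and lower numbers for stronger inhibition of growth:

Compound 1, `N#CCC1=NN=C(c2ccc(Br)cc2)C(CC(=O)c2ccc(Br)cc2)O1`, gives 22100 nM.
Compound 2, `N#CCC1=NN=C(c2ccc(Br)cc2)C(CC(=O)c2ccc([N+](=O)[O-])cc2)O1`, gives 23000 nM.
Compound 3, `N#CCC1=C(C#N)CC(c2ccc([N+](=O)[O-])cc2)=C(CC(=O)c2ccc([N+](=O)[O-])cc2)O1`, gives 80 nM.

Compounds 1 and 2 share one core and differ in a single place: bromo in place of nitro on an aromatic carbon. That change made a 1.0-fold lower number from compound 2 to compound 1 (0.02 log units; within the scatter), so the two values show no separation in this assay. Compound 3 stands on a different core, and the difference between the two cores is not broken down here; what the values show is that compound 3 sits far from both compound 1 and compound 2, with a gap well beyond the scatter in each case.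

Compound 4, `N#CCC1=C(C#N)CC(c2ccc([N+](=O)[O-])cc2)=C(CC(=O)c2ccc(Br)cc2)O1`, has not yet been measured. It stands to compound 3 as compound 1 stands to compound 2: bromo in place of nitro on an aromatic carbon. Among these compounds the change occurs twice in all, and the places are described in the same words, so it is the same change on a different core. Going by the values given here, the only measured instance of it, a 1.0-fold lower number from compound 2 to compound 1 (0.02 log units; within the scatter), lies within the scatter. Among the compounds with values here, on that basis the step from compound 3 to compound 4 is expected to be small as well, estimated as a 1.1-fold higher number from compound 3 to compound 4 (0.05 log units; within the scatter), resting on the single measured step and on compound 3 giving 80 nM. Compound 4 is therefore estimated to give 90 nM in this assay, with a likely range from 30 nM to 300 nM, the width reflecting that the change has been seen only once and on another core.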

Compound 4, concentration for 50% growth inhibition: 3600 nM
Compound 4: middle estimate off by 40-fold (1.60 log units), on the low side; the measured number lies above the stated range.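

In this assay, the change from 4-nitrophenyl to 4-bromophenyl on the core of compound 3 gave a 45-fold higher number from compound 3 to compound 4 (1.65 log units; beyond the scatter), whereas on the core of compound 1 the same change gave a 1.0-fold lower number from compound 2 to compound 1 (0.02 log units; within the scatter), which lies within the scatter. A step read on one core therefore did not carry over to the other in this series, and the flat result on the core of compound 1 gave no guide to the large loss of growth inhibition on the core of compound 3: the same change on two cores in this assay, a 1.0-fold lower number (0.02 log units; within the scatter) from compound 2 to compound 1 and a 45-fold higher number (1.65 log units; beyond the scatter) from compound 3 to compound 4, 47-fold (1.67 log units) apart, beyond the scatter of two such steps This shows that the size of the step depends on the core, but it rests on one pair per core, and the two cores differ in more than one place, so it does not show which part of the core makes the difference or why.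

The compounds shown leave open whether an amine, a carboxylic acid or a methoxy group in the same place would track the large step on the core of compound 3 or the flat one on the core of compound 1. They also leave open how that core would respond if the remaining 4-nitrophenyl group of compound 4 were replaced by 4-bromophenyl.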